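A few compounds are considered here, and "the series" means these few. Any claim that something is new, unique, unknown or untested is made for them only; others in the source may bear on it.

Compound 1, `COc1ccc(/C=C/C(=O)c2ccc(OC)c3c2OC(C)(C)C=C3)c(F)c1`, is a chalcone-type molecule carrying a 2-fluoro-4-methoxyphenyl group on the double-bonded chain. Among the measured compounds shown here, in a functional assay on SW-620 cells (Homo sapiens) for antiproliferative activity, read by MTT assay, with a stated time of 24 h (a lower number here means a stronger inhibitor, a higher number a weaker inhibitor), compound 1 gives 6570 nM, and this is the only plain number among the two values so far. Compound 2, `COc1ccc(C(=O)/C=C/c2ccc(N(c3ccccc3)c3ccccc3)cc2)c2c1C=CC(C)(C)O2`, reaches only a limit of the assay, > 10000 nM, which is the limit of > 10000 nM in this assay, at which 1 of the 2 values shown sits. Compound 3, `COc1ccc(C(=O)/C=C/c2ccccc2Cl)c2c1C=CC(C)(C)O2`, is not yet measured; it differs from compound 1 by 2-chlorophenyl in place of 2-fluoro-4-methoxyphenyl on a double-bonded chain carbon bound to a double-bonded chain carbon. For the measured compounds named here, no measured pair in the set spans a change of this kind, so the size of the step in this assay cannot be read off from existing data. Given that compound 1 itself sits at a modest 6570 nM, a step from compound 1 to compound 3 of a 1.4-fold higher number from compound 1 to compound 3 (0.14 log units; within the scatter) toward weaker inhibition is expected, perhaps only marginally beyond the scatter. Compound 3 is therefore estimated at 9000 nM, within a range from 3000 nM to 25000 nM.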

Compound 3, half-maximal inhibitory concentration: > 10000 nM
Compound 3: only a limit was reported; the forecaster's own chance of this, stated with the estimate: 35%; middle value at least 1.1-fold (0.04 log units) away from the limit.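

Among the compounds shown here, putting 2-chlorophenyl in place of 2-fluoro-4-methoxyphenyl on a double-bonded chain carbon bound to a double-bonded chain carbon gives the only readable step at this position in this assay, an at least 1.5-fold higher number from compound 1 to compound 3 (0.18 log units; that floor lies within the scatter). That step is a floor and not a size, so the true gap may be small or much larger. Compound 1 remains the only compound here with a plain number, and the other values gather at a single limit of the assay: the limit of > 10000 nM in this assay, at which 2 of the 3 values shown sit.

Open, going by these compounds, is whether the step follows the loss of the methoxy group or the swap of fluorine for chlorine, as the two go together in this change. Also open, on these data alone, is how a phenyl ring carrying a dimethylamino group or a carboxylic acid would read at this position.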